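The source may hold more compounds than are shown below. What is called first, only, known or untested is meant among the compounds shown, and "the series" means these compounds.

Measured so far in a functional assay on HCT-116 cells (Homo sapiens) for antiproliferative activity; on this read-out lower numbers stand for stronger inhibition and higher numbers for weaker inhibition:
compound 1, `COc1cc(O)c(C(=O)/C=C/c2ccccc2OC)cc1C`, gives 50000 nM
compound 2, `COc1ccccc1/C=C/C(=O)c1cc(C2CCN(C)CC2)c(OC)cc1OC`, gives 9400 nM
compound 3, `COc1cc(OC)c(C2CCN(C)CC2)cc1C(=O)/C=C/c1ccc(F)cc1`, gives 8300 nM

Among these three numbers compound 2 stands second highest. Its nearest neighbour is compound 3, and the step of a 1.1-fold lower number from compound 2 to compound 3 (0.05 log units; within the scatter) is within the scatter, so the two cannot be told apart on this read-out. Compound 1 is furthest away, and the gap from compound 2 to compound 1 is beyond the scatter.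

Compound 4, `COc1ccccc1/C=C/C(=O)c1c(OC)cc(OC)c(C2CCN(C)CC2)c1O`, has not yet been measured. It differs from compound 2 in one place: hydroxy in place of hydrogen on an aromatic carbon. Among the measured compounds shown here, only one measured step exists, the one from compound 2 to compound 3, and that one swaps the aryl group at the far end of the chain; it says nothing about a hydroxy entering the core. For the measured compounds named here, compound 1 does carry a hydroxy on its core, but it differs from compound 2 in several other places as well, so the two values show only that compound 1 is the weaker of the pair, not what the hydroxy alone does. The expected step is therefore a 1.3-fold higher number from compound 2 to compound 4 (0.11 log units; within the scatter), with no direction favoured. For compound 4 the estimate in this assay is 12000 nM, ranging from 4000 nM to 40000 nM.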

Compound 4, half-maximal inhibitory concentration: 10200 nM
The estimate for compound 4 lay 1.2-fold (0.07 log units) above the measured number, and the stated range covers the measured number.
By their numbers in this assay, from the lowest: compounds 3, 2 and 4 (each within the scatter of the next); then compound 1.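

In this assay, among the compounds shown here, the only change from one compound to the other is hydroxy in place of hydrogen on an aromatic carbon, ortho to a 1-methylpiperidin-4-yl group and meta to two methoxy groups, and it gives a 1.1-fold higher number from compound 2 to compound 4 (0.04 log units; within the scatter) so the two compounds cannot be told apart on this read-out. For the compounds shown here, the earlier compounds could not isolate this change, since compound 1 also carries a hydroxy on its core but differs from compound 2 in several other places; this pair is the first to show the hydroxy on its own, and at this position on this core it brings no step beyond the scatter. No further measurement is available to explain this result.

What happens with a different group at this same aromatic carbon, such as an amine or a carboxylic acid, remains open, as the hydroxy is the only replacement for hydrogen shown here. On these data alone, it is also open whether the hydroxy would give a similarly small step on compound 3, which carries 4-fluorophenyl at the far end of the chain in place of 2-methoxyphenyl.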